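Compound 2 to compound 3: giving up (oxolan-2-yl)methoxy

The source may report more compounds than this note shows. Statements on the series, on what has been measured and on what is new or still open speak of the compounds shown alone.

Compound 2 (`NCc1ccc(C(=O)Nc2ccncc2F)cc1-c1cccc(C(=O)OCC2CCCO2)c1`) stands at < 0.0834 h in an ADME assay on a cell-free system (plasma, Homo sapiens) for metabolic stability, read by LC-MS (a lower number here means that the compound disappears faster, a higher number that the compound lasts longer), which is a limit of the assay. Compound 1 (`NCc1ccc(C(=O)Nc2ccncc2F)cc1-c1cccc(NC(=O)c2cccc(C(=O)O)c2)c1`) gives > 2 h, also a limit. Compound 3 (`NCc1ccc(C(=O)Nc2ccncc2F)cc1-c1cccc(C(=O)Nc2ccc(CC(=O)O)cc2)c1`) carries (4-(carboxymethyl)phenyl)amino in place of (oxolan-2-yl)methoxy on a carbonyl carbon. Among the compounds with values here, the one measured step bearing on this change is large and beyond the scatter: an at least 23-fold lower number from compound 1 to compound 2 (1.37 log units; beyond the scatter). That step brought in the (oxolan-2-yl)methoxy group that compound 3 gives up. A large rise is therefore expected, and the estimated step is an at least 35-fold higher number from compound 2 to compound 3 (1.55 log units; beyond the scatter). The estimate for compound 3 in this assay is 3 h, with an expected range of 1 h to 8 h.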

Compound 3, half-life: > 2 h
Compound 3 ended at the assay's limit; the forecaster's own chance of this, stated with the estimate: 75%; the middle value does not contradict the limit.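

In this assay, the carbonyl carbon stays in place and only its substituent changes, giving an at least 23-fold higher number from compound 2 to compound 3 (1.37 log units; beyond the scatter). The carbonyl on the aromatic carbon therefore does not by itself bring the low number; with (4-(carboxymethyl)phenyl)amino on it, the number reaches the upper limit of the assay, as it does for the differently linked compound 1. The true size of the step remains unknown, since both ends are limits: the limit of < 0.0834 h in this assay, at which 1 of the 3 values shown sits.

Open, as far as these compounds go, is whether the oxolane ring or the oxygen link matters, which a plain methoxy or a simple phenylamino on the same carbonyl carbon would separate. From the compounds shown here alone, the part played by the carboxylic acid in (4-(carboxymethyl)phenyl)amino also remains open.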